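The compounds below may be only part of what the source reports. "The series", "measured", "known", "first", "only" and "open" are said of these compounds alone.

The measured compounds:
Compound 1, `CN(C)c1cccc2c1ccn2S(=O)(=O)c1ccccc1`, gives 65 nM in an assay on isolated protein for displacement of a labelled ligand from 5-hydroxytryptamine receptor 6 (Homo sapiens), read by scintillation counting, with a stated time of 1 h; on this read-out lower numbers stand for stronger inhibition and higher numbers for weaker inhibition.
Compound 2, `CN(C)c1cccc2c1ccn2S(C)(=O)=O`, gives 4720 nM in this assay.

Among the compounds with values here, of these two numbers, compound 2 holds the higher one, the weaker end of what has been measured so far; its only neighbour is compound 1, and the step between them, a 73-fold higher number from compound 1 to compound 2 (1.86 log units; beyond the scatter), is the single measured step available. That step concerns the group carried by the sulfonyl sulfur, the same part of the molecule that changes next.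

Compound 3, `CCCCS(=O)(=O)n1ccc2c(N(C)C)cccc21`, has not yet been measured. It differs from compound 2 by propyl in place of hydrogen on a saturated chain carbon bound to a sulfonyl sulfur; read one bond further out, the methyl on the sulfonyl sulfur becomes a butyl. Within the data shown here, the one measured step that bears on this, a 73-fold higher number from compound 1 to compound 2 (1.86 log units; beyond the scatter), was large, and it showed the number rising sharply when the group on that sulfur shrank from a ring to a single carbon. Among the measured compounds shown here, a butyl chain sits between methyl and phenyl in how much it adds, so a partial reversal seems plausible, though no measured compound shows a chain of this kind.

Compound 3 is therefore expected to give a lower number than its methyl parent, a 3.1-fold lower number from compound 2 to compound 3 (0.50 log units; beyond the scatter), with some uncertainty, because the large step of a 73-fold higher number from compound 1 to compound 2 (1.86 log units; beyond the scatter) ran the opposite way when the group on the sulfonyl sulfur was made smaller. The estimate for compound 3 is 1500 nM, with a range from 400 nM to 5000 nM.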

Compound 3, inhibition constant: 49900 nM
Estimate against measurement, compound 3: 33-fold (1.52 log units) below; measured number outside the range, above it.
By their numbers in this assay, from the lowest: compound 1; then compound 2; then compound 3.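

In this assay, the butyl chain does not win back what was lost when phenyl gave way to methyl on the sulfonyl sulfur: methyl to butyl gives an 11-fold higher number from compound 2 to compound 3 (1.02 log units; beyond the scatter) and runs in the same direction as a 73-fold higher number from compound 1 to compound 2 (1.86 log units; beyond the scatter) rather than partly reversing it. Measured directly against the ring, the chain gives a 770-fold higher number from compound 1 to compound 3 (2.89 log units; beyond the scatter) and so places compound 3 at the weak end of the three, which means that adding carbon to this group does not by itself lower the number: compound 3 has more carbon on the sulfur than compound 2 and a higher number, while compound 1, with phenyl, goes the other way and has the lowest number. Nothing available here accounts for this result.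

The compounds shown leave open whether a shorter chain such as ethyl, or a saturated ring such as cyclohexyl, would fall nearer compound 1 or nearer compound 3. Also open, as far as these compounds go, is how a phenyl carrying a fluorine or a methoxy group would compare with the plain phenyl of compound 1, and whether these steps would keep their size with a change elsewhere on the shared core.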